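Compound 4: a 1-phenylethyl amide after three level neighbours

The source may report more compounds than this note shows. Statements on the series, on what has been measured and on what is new or still open speak of the compounds shown alone.

compound 1 `CCCCc1oc2ccccc2c1C(=O)c1ccc(OCC(=O)NC(C)C)cc1` gives 17500 nM
compound 2 `CCCCNC(=O)COc1ccc(C(=O)c2c(CCCC)oc3ccccc23)cc1` gives 22800 nM
compound 3 `CCCCc1oc2ccccc2c1C(=O)c1ccc(OCC(=O)Nc2ccccc2)cc1` gives 25900 nM

In a functional assay on U-937 cells (Homo sapiens) for antiproliferative activity, read by MTT assay, with a stated time of 24 h (a higher number here means a weaker inhibitor, a lower number a stronger inhibitor), compound 3 gives 25900 nM and stands level with compounds 1 and 2, from which the scatter does not separate it. Compound 4 `CCCCc1oc2ccccc2c1C(=O)c1ccc(OCC(=O)N[C@@H](C)c2ccccc2)cc1` carries 1-phenylethyl in place of phenyl on an amide-type nitrogen. Three measured steps at that nitrogen bear on this: a 1.3-fold higher number from compound 1 to compound 2 (0.11 log units; within the scatter) for butyl in place of isopropyl, a 1.5-fold higher number from compound 1 to compound 3 (0.17 log units; within the scatter) for phenyl in place of isopropyl, and a 1.1-fold higher number from compound 2 to compound 3 (0.06 log units; within the scatter) for phenyl in place of butyl. Each lies within the scatter. Within the data shown here, none of the measured compounds has a defined stereocentre, so that part of the change is untested. No shift beyond the scatter is therefore expected in this assay for this change. An estimated 1.3-fold lower number from compound 3 to compound 4 (0.11 log units; within the scatter) is what these steps suggest. For compound 4 the estimated value is 20000 nM with an expected range from 10000 nM to 40000 nM in this read-out.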

Compound 4, half-maximal inhibitory concentration: 33800 nM
Estimate against measurement, compound 4: 1.7-fold (0.23 log units) below; the measured number falls inside the stated range.
By their numbers in this assay, from the lowest: compounds 1, 2, 3 and 4 (each within the scatter of the next).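

In this assay the groups at the amide-type nitrogen now include 1-phenylethyl, which has more heavy atoms than phenyl and a defined stereocentre, and it stays within the scatter of phenyl (a 1.3-fold higher number from compound 3 to compound 4 (0.12 log units; within the scatter)), butyl (a 1.5-fold higher number from compound 2 to compound 4 (0.17 log units; within the scatter)) and isopropyl (a 1.9-fold higher number from compound 1 to compound 4 (0.29 log units; within the scatter)). Across these four compounds, the groups with an aromatic ring at this nitrogen do not separate from the two without one in this read-out. Nothing measured here offers an explanation for this flat response.

Going by these compounds, whether the opposite configuration of the 1-phenylethyl stereocentre would read the same remains open. On these data alone, it is also open whether a carboxylic acid, an amine or a longer chain on this nitrogen would shift the number beyond the scatter.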